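The source may report more compounds than this note shows. Statements on the series, on what has been measured and on what is new or still open speak of the compounds shown alone.

Compound 1 `Cc1nn(C)c(Oc2ccc(F)cc2)c1/C=N\CCCCCOc1cc2oc(=O)cc(C)c2cc1Cl`: in a functional assay on U-87MG ATCC cells for antiproliferative activity against U-87 MG (Homo sapiens), read by MTT assay, with a stated time of 72 h (a lower number here means a stronger inhibitor, a higher number a weaker inhibitor), compound 1 gives > 25000 nM, which is a limit of the assay and not a number.
Compound 2 `Cc1nn(C)c(Oc2ccc(I)cc2)c1/C=N\CCCCCOc1cc2oc(=O)cc(C)c2cc1Cl`: in this assay compound 2 gives > 25000 nM, again a limit.
Compound 3 `Cc1nn(C)c(Oc2ccccc2F)c1/C=N\CCCCCCOc1cc2oc(=O)cc(C)c2cc1Cl`: in this assay compound 3 gives > 25000 nM, also a limit.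

Compound 3 therefore stands only at a limit, and the two other values shown are limits of the same kind (the limit of > 25000 nM in this assay, at which 3 of the 3 values shown sit). For the measured compounds named here, the single measured step, a step that the two limits leave unreadable from compound 1 to compound 2, cannot be read in size, since both of its ends are limits.

Compound 4 `Cc1nn(C)c(Oc2ccc(F)cc2)c1/C=N\CCCCCCOc1cc2oc(=O)cc(C)c2cc1Cl` differs from compound 3 by 4-fluorophenyl in place of 2-fluorophenyl on an oxygen on an aromatic ring. Going by the values given here, no measured step concerns the position of fluorine on the phenoxy group; the one measured step involves iodo in place of fluoro and gives no readable size. Among the compounds with values here, nothing among the measured compounds suggests that compound 4 would leave the limit, and the step that the limit leaves unreadable from compound 3 to compound 4 is expected to be none beyond the scatter. Compound 4 is thus expected to give about 35000 nM in this assay, within 15000 nM to 120000 nM.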

Compound 4, half-maximal inhibitory concentration: 16700 nM
The estimate for compound 4 lay 2.1-fold (0.32 log units) above the measured number; the measured number falls inside the stated range.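

In this assay compound 4 gives 16700 nM, and it is the only compound shown with a number and not a limit, so the fluorine position on the phenoxy group is the one change here with a partly readable outcome. Moving to 4-fluorophenyl in place of 2-fluorophenyl on an oxygen on an aromatic ring gives an at least 1.4-fold lower number from compound 3 to compound 4 (0.17 log units; that floor lies within the scatter), so the change cannot be claimed as beyond the scatter, although the true step may be larger. All the other compounds remain at the limit: the limit of > 25000 nM in this assay, at which 3 of the 4 values shown sit.

As far as these compounds go, it remains open how far a 4-chlorophenyl or 4-methoxyphenyl group on the same oxygen would move the number. For the compounds shown here, the effect of a chain longer than the one in compound 4, or of an amine at the end of that chain, also remains open.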